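The compounds below may be only part of what the source reports. "The series", "measured", "known", "first", "only" and "open" are said of these compounds alone.

Measured compounds in the series:
Compound 1 `CNc1cc(Oc2c(OC)cc3cc(C#N)ccc3c2OC)nc(Nc2ccc(C#N)cc2)n1` in an ADME assay on MT4 cells (Homo sapiens) for cytotoxicity, read by MTT assay, with a stated time of 5 days (a lower number here means that less compound is tolerated, a higher number that more compound is tolerated), gives 239000 nM.
Compound 2 `CCNc1cc(Oc2c(OC)cc3cc(C#N)ccc3c2OC)nc(Nc2ccc(C#N)cc2)n1` gives in this assay only a limit of the assay, > 125000 nM.
Compound 3 `CCC(C)Nc1cc(Oc2c(OC)cc3cc(C#N)ccc3c2OC)nc(Nc2ccc(C#N)cc2)n1` gives in this assay only a limit of the assay, > 125000 nM.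

The change methyl in place of hydrogen on a saturated chain carbon bound to a nitrogen on an aromatic ring produces the step that the limit leaves unreadable from compound 1 to compound 2; its size cannot be read because of the limit of > 125000 nM in this assay, at which 2 of the 3 values shown sit. Between compound 1 and compound 3 the cores differ by sec-butyl in place of methyl on a nitrogen on an aromatic ring.

Compound 4 `CCC(CC)Nc1cc(Oc2c(OC)cc3cc(C#N)ccc3c2OC)nc(Nc2ccc(C#N)cc2)n1` carries the change (methyl in place of hydrogen on a saturated chain carbon, two bonds along the chain from a nitrogen on an aromatic ring). Around the place this differs from the earlier change: there the carbon was bound to a nitrogen on an aromatic ring, here it sits two bonds along the chain from that nitrogen, so this is the same kind of change, not the same one. The expectation for compound 4 rests on compound 3, which in this assay gives only the limit > 125000 nM. Compound 4 is expected to remain near that limit, an estimated step that the limit leaves unreadable from compound 3 to compound 4. The estimated value for compound 4 in this assay is 150000 nM, expected between 70000 nM and 320000 nM.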

Compound 4, half-maximal cytotoxic concentration: > 125000 nM
Compound 4 was reported as a limit; the forecaster's own chance of this, stated with the estimate: 75%; the middle value is on the limit's open side.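

No step to compound 4 from compound 1, compound 2 or compound 3 can be read: the limit of > 125000 nM in this assay, at which 3 of the 4 values shown sit.

The compounds shown leave open where the values of compound 2, compound 3 and compound 4 lie beyond their limits, and whether these chain changes shift tolerance at all.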